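Swapping a tetrazole for a methylimidazole: half-life expected to fall

The source may report more compounds than this note shows. Statements on the series, on what has been measured and on what is new or still open speak of the compounds shown alone.

Values in an ADME assay on microsomes from liver (Homo sapiens) for metabolic stability; on this read-out higher numbers stand for a longer-lived compound and lower numbers for a shorter-lived compound:
- compound 1 `CC(C)C(Cc1nnc[nH]1)c1ccc(-c2ccc3cccc(F)c3c2)[nH]c1=O`: 0.307 h
- compound 2 `Cc1nc(C(c2ccc(-c3ccc4cccc(F)c4c3)[nH]c2=O)C(C)C)[nH]c1C`: 0.268 h
- compound 3 `CC(C)C(Cc1nnn[nH]1)c1ccc(-c2ccc3cccc(F)c3c2)[nH]c1=O`: > 3 h (a limit)

Compound 3 stands at > 3 h, which is a limit of the assay and not a number. Compound 4 `Cc1c[nH]c(C(c2ccc(-c3ccc4cccc(F)c4c3)[nH]c2=O)C(C)C)n1` has 4-methyl-1H-imidazol-2-yl in place of (1H-tetrazol-5-yl)methyl on a saturated chain carbon bound to an aromatic carbon and a saturated chain carbon. The closest measured step, an at least 11-fold higher number from compound 2 to compound 3 (1.04 log units; beyond the scatter), is large and runs the opposite way. The step of an at least 9.7-fold higher number from compound 1 to compound 3 (0.98 log units; beyond the scatter) also lies beyond the scatter, while a 1.1-fold lower number from compound 1 to compound 2 (0.06 log units; within the scatter) stays within it. The imidazole of compound 4 therefore points to a reading near compound 2 at 0.268 h. A large fall is expected in this assay, an at least 10-fold lower number from compound 3 to compound 4 (1.00 log units; beyond the scatter). Compound 4 is estimated at 0.3 h, with an expected range of 0.15 h to 0.6 h.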

Compound 4, half-life: 0.09 h
Compound 4: the middle estimate sits 3.3-fold (0.52 log units) above what was measured; measured number below the stated range.
By their numbers in this assay, from the lowest: compound 4; then compounds 2 and 1 (each within the scatter of the next). At a limit, above all of these: compound 3.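

In this assay compound 3 gives > 3 h, which is a limit and not a number. Putting 4-methyl-1H-imidazol-2-yl at this place gives a large drop, an at least 33-fold lower number from compound 3 to compound 4 (1.52 log units; beyond the scatter), and the new compound also falls short of the triazole, a 3.4-fold lower number from compound 1 to compound 4 (0.53 log units; beyond the scatter). New here is that a single methyl on the imidazole matters, with hydrogen in its place giving a 3.0-fold lower number from compound 2 to compound 4 (0.47 log units; beyond the scatter). Still open, from the compounds shown here alone, is whether an ethyl group on the imidazole would lengthen the half-life further, and whether a carboxylic acid at this place would match the tetrazole.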